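The source may hold more compounds than are shown below. What is called first, only, known or untested is meant among the compounds shown, and "the series" means these compounds.

Working notes on the series in a functional assay on KB cells (Homo sapiens) for cytotoxicity; on this read-out higher numbers stand for weaker inhibition and lower numbers for stronger inhibition. Compound 1 `Cc1ccccc1Cn1cc(C(N)=O)c2c(N)ncnc21` reaches only a limit of the assay in this assay, > 100000 nM. Compound 2 `COCCOCn1cc(C(N)=O)c2c(N)ncnc21` likewise gives only a limit in this assay, > 100000 nM. The step that the two limits leave unreadable from compound 1 to compound 2 is therefore unreadable, since both ends sit at the limit of > 100000 nM in this assay, at which 2 of the 3 values shown sit. Within the data shown here, compound 3 `Cc1ccc(Cn2cc(C(=N)S)c3c(N)ncnc32)cc1` is the single member with a number in this assay, 65000 nM, and so stands alone among the three values shown.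

Compound 4 `Cc1ccc(Cn2cc(C(N)=O)c3c(N)ncnc32)cc1` differs from compound 3 only in the change (a group of 3 heavy atoms (1 carbon, 1 nitrogen, 1 oxygen; no ring) in place of a group of 3 heavy atoms (1 carbon, 1 nitrogen, 1 sulfur; no ring), on an aromatic carbon). Among the measured compounds shown here, no measured step covers this change directly: the one step measured cannot be sized, and compounds 1 and 2, which already carry the carbamoyl group that enters, both return limits. For the measured compounds named here, the carbamoyl-bearing members thus offer no number to anchor the comparison; compound 3, with the sulfur-bearing group, is the sole point with a reading. Compound 4 is expected to move in the direction of weaker inhibition, an estimated step of a 2.0-fold higher number from compound 3 to compound 4 (0.30 log units; within the scatter). The estimated value for compound 4 is 130000 nM, with a range from 40000 nM to 400000 nM, and a limit rather than a number is the more likely outcome.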

Compound 4, half-maximal inhibitory concentration: > 100000 nM
Compound 4 gave a limit, no number; the forecaster's own chance of this, stated with the estimate: 65%; the middle value lies beyond the limit too.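

In this assay, carbamoyl in place of the sulfur-bearing group on the aromatic carbon now has a first bound, an at least 1.5-fold higher number from compound 3 to compound 4 (0.18 log units; that floor lies within the scatter). Only a floor can be read and it lies within the scatter, so the result does not establish a real difference between the two groups at this position; the true size of the step may be larger, but the limit hides it. With the 4-methylphenyl group now also tested alongside carbamoyl, the carbamoyl members give no number with any of the three groups on the saturated chain carbon, and the steps among compound 1, compound 2 and compound 4 cannot be read: the limit of > 100000 nM in this assay, at which 3 of the 4 values shown sit.

Going by these compounds, whether a carboxylic acid or a nitrile on the same aromatic carbon gives a number inside the range of the assay stays open, as does the effect of an amine in place of the 4-methylphenyl group. Also open, on these data alone, is whether the sulfur-bearing group still gives a number when 2-methylphenyl or 2-methoxyethoxy stands on the saturated chain carbon, as it does in compound 3 at 65000 nM with 4-methylphenyl.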